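Methoxy for Fluoro on a Non-Toxic Pair of Thioether Ketones

The source may report more compounds than this note shows. Statements on the series, on what has been measured and on what is new or still open speak of the compounds shown alone.

This account concerns three measured compounds and one that is still to be measured. Compound 1 `Cc1c(Cc2c(F)cccc2Cl)nc(SCC(=O)c2ccc(F)cc2)[nH]c1=O` was tested in an ADME assay on MT4 cells (Homo sapiens) for cytotoxicity, read by MTT assay (on this read-out lower numbers stand for higher toxicity in this test and higher numbers for lower toxicity in this test), and gave only a limit of the test, > 59000 nM. Compound 2 `COc1ccc(C(=O)CSc2nc(Cc3c(F)cccc3Cl)c(C)c(=O)[nH]2)cc1` carries the change methoxy in place of fluoro on an aromatic carbon relative to compound 1. In this assay compound 2 likewise gave only a limit, > 12000 nM. The step that the two limits leave unreadable from compound 1 to compound 2 therefore cannot be read as a number, because the limit of > 59000 nM in this assay, at which 1 of the 3 values shown sits, and the limit of > 12000 nM in this assay, at which 1 of the 3 values shown sits, are both limits rather than values. Compound 3 `CC(C)c1c(Cc2c(F)cccc2F)nc(SCC(=O)c2ccc(F)cc2)[nH]c1=O` rests on a different core; the difference between the two cores is not broken down here. In this assay compound 3 also gave only a limit, > 58000 nM, which is described by the limit of > 58000 nM in this assay, at which 1 of the 3 values shown sits.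

Compound 4 `COc1ccc(C(=O)CSc2nc(Cc3c(F)cccc3F)c(C(C)C)c(=O)[nH]2)cc1` differs from compound 3 by methoxy in place of fluoro on an aromatic carbon, the same change that leads from compound 1 to compound 2, at a place described in the same words. Since the earlier step of this change left no readable size, nothing in the measured data points to a shift in this assay from compound 3 to compound 4. The step is expected to be an at least 1.1-fold lower number from compound 3 to compound 4 (0.06 log units; that floor lies within the scatter). In this assay compound 4 is estimated at 50000 nM, with an expected range from 12000 nM to 120000 nM, and most likely the test will again report only a limit.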

Compound 4, half-maximal cytotoxic concentration: 33000 nM
The estimate for compound 4 lay 1.5-fold (0.18 log units) above the measured number, and the stated range covers the measured number.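

In this assay the change from 4-fluorophenyl to 4-methoxyphenyl now yields an at least 1.7-fold lower number from compound 3 to compound 4 (0.24 log units; that floor lies within the scatter), and since only a floor is known and that floor lies within the scatter, this shows no more than that a lower number is possible on this core. The same change on the core of compound 1 cannot be read as a step, because compound 2, like compound 1, gave only a limit of the test: the limit of > 12000 nM in this assay, at which 1 of the 4 values shown sits. With no size from that core to set beside the new one, the data neither show that the change carries from one core to the other nor show that it behaves differently on each, and they show no real loss of tolerance on either.

The compounds shown leave open how large the step truly is on either core, since one end of it or both ends remain limits in this assay. They also leave open what an amine or a carboxylic acid would do at the same place on the ring that carries the fluoro or methoxy group, and whether a longer chain such as ethoxy would follow the methoxy compounds.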